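Sulfonamide Series: Replacing the Aryl Group With a Small Ester

The source may report more compounds than this note shows. Statements on the series, on what has been measured and on what is new or still open speak of the compounds shown alone.

Compound 1 `COc1ccc(Cl)cc1S(=O)(=O)Nc1cncc(C(=O)Nc2ccccc2)c1`: 310 nM
Compound 2 `COc1ccc(C(N)=O)cc1S(=O)(=O)Nc1cccnc1`: 1490 nM
Compound 3 `COc1ccc(Cl)cc1S(=O)(=O)Nc1cncc(-c2ccccc2C)c1`: 178 nM

Of the compounds shown here, three sharing a sulfonamide core have been measured in an assay on isolated protein for inhibition of alkaline phosphatase, tissue-nonspecific isozyme (Homo sapiens); a lower number here means a stronger inhibitor, a higher number a weaker inhibitor. Compound 3 gives the lowest of the three numbers, 178 nM, but its neighbour compound 1, at 310 nM, lies within the scatter of it; only compound 2, at 1490 nM, sits clearly higher. Among the compounds with values here, the one single-point step available, a 1.7-fold lower number from compound 1 to compound 3 (0.24 log units; within the scatter), stays within the scatter, so swapping one large group for another on that aromatic carbon changed little.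

Compound 4 `COC(=O)c1cncc(NS(=O)(=O)c2cc(Cl)ccc2OC)c1` is not yet measured. It differs from compound 3 as follows: methoxycarbonyl in place of 2-methylphenyl on an aromatic carbon. Within the data shown here, this step has no direct precedent. The step from compound 1 to compound 3 exchanged two large groups; here a ring is removed and a much smaller, acceptor-bearing group enters. The comparison with compound 2, which carries no group at all at this place and gives the highest number, suggests that shrinking this substituent may raise the number, though compound 2 also differs elsewhere, so it is only a loose guide. Compound 4 is therefore expected to be a weaker inhibitor, with an estimated step of a 3.4-fold higher number from compound 3 to compound 4 (0.53 log units; beyond the scatter). The estimate for compound 4 is 600 nM, within a range of 200 nM to 2000 nM.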

Compound 4, half-maximal inhibitory concentration: 65 nM
Compound 4: middle estimate off by 9.2-fold (0.97 log units), on the high side; measured number below the stated range.
By their numbers in this assay, from the lowest: compound 4; then compounds 3 and 1 (each within the scatter of the next); then compound 2.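

In this assay, this place on the aromatic carbon, two atoms from the ring nitrogen, does not need a large ring-bearing group: methoxycarbonyl in place of 2-methylphenyl gives a 2.7-fold lower number from compound 3 to compound 4 (0.44 log units; beyond the scatter), so a group with no ring and fewer heavy atoms does better here. Keeping the carbonyl and changing only what hangs on it, methoxy in place of anilino, gives a 4.8-fold lower number from compound 1 to compound 4 (0.68 log units; beyond the scatter), which shows that the part beyond the carbonyl also affects the number and that the anilino ring is not required at this place. Nothing at hand explains why the ester gives the lower number in either step.

On these data alone, it remains open whether the lower number goes with the ester as such or simply with the loss of the ring, and a carboxylic acid, a small N-methyl amide or the longer ethoxycarbonyl at this place would help to separate the two. As far as these compounds go, it is also open whether the gain from the methoxycarbonyl group would persist with a different group in place of the chlorine on the other ring.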